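A Methylsulfanyl-to-Selenium Exchange Tested on Two Cores

The source may report more compounds than this note shows. Statements on the series, on what has been measured and on what is new or still open speak of the compounds shown alone.

Compound 1 `CS/C(=N\C(=O)c1csc([N+](=O)[O-])c1)NC(=O)c1csc([N+](=O)[O-])c1` and compound 2 `CS/C(=N\C(=O)c1ccco1)NC(=O)c1ccco1` are built around the same kind of carbon with a double bond to nitrogen, but the difference between their two cores is not broken down here. In a functional assay on HT-29 cells (Homo sapiens) for cytotoxicity, read by MTT assay, with a stated time of 72 h (a higher number here means a weaker inhibitor of growth, a lower number a stronger inhibitor of growth), compound 1 gives 51800 nM, and compound 2 gives 77100 nM, two numbers within the usual scatter of each other. Compound 3 `O=C(/N=C(/NC(=O)c1ccco1)[Se]Cc1ccccc1)c1ccco1` carries a group of 8 heavy atoms (7 carbon, 1 selenium; one six-membered aromatic ring of carbon only) in place of a group of 2 heavy atoms (1 carbon, 1 sulfur; no ring), on a carbon with a double bond to nitrogen and gives 7190 nM in this assay, a step of an 11-fold lower number from compound 2 to compound 3 (1.03 log units; beyond the scatter). Compound 4 `O=C(/N=C(/NC(=O)c1csc([N+](=O)[O-])c1)[Se]Cc1ccccc1)c1csc([N+](=O)[O-])c1`, not yet measured, carries the same change on the core of compound 1, namely (a group of 8 heavy atoms (7 carbon, 1 selenium; one six-membered aromatic ring of carbon only) in place of a group of 2 heavy atoms (1 carbon, 1 sulfur; no ring), on a carbon with a double bond to nitrogen). For compound 4 a step of a 9.4-fold lower number from compound 1 to compound 4 (0.97 log units; beyond the scatter) is expected, since compound 1 gives 51800 nM and the matching change made an 11-fold lower number from compound 2 to compound 3 (1.03 log units; beyond the scatter). Compound 4 is therefore estimated at 5500 nM in this assay, with a likely range from 1500 nM to 20000 nM.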

Compound 4, concentration for 50% growth inhibition: 9250 nM
Beside the measured number, compound 4's estimate is 1.7-fold (0.23 log units) below it; low and high end bracket the measured number.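

On the core of compound 1, exchanging methylsulfanyl for the selenium-bearing group again strengthens growth inhibition in this assay, with a 5.6-fold lower number from compound 1 to compound 4 (0.75 log units; beyond the scatter). Set beside the step on the other core, the two do not differ beyond the usual scatter: the same change on two cores in this assay, an 11-fold lower number (1.03 log units; beyond the scatter) from compound 2 to compound 3 and a 5.6-fold lower number (0.75 log units; beyond the scatter) from compound 1 to compound 4, 1.9-fold (0.28 log units) apart, within the scatter of two such steps. This shows the change carrying over between these two cores in this one assay, but the selenium and the aromatic ring enter together and the data do not separate them, nor do they show that it would carry over to any other core.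

The compounds shown leave open whether a sulfur atom carrying the same ring, or a selenium atom carrying a methyl group, would give a similar step. They also leave open how a longer chain or an amine would read in that place.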